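Replacing methylsulfanyl on the shared core: toward compound 3

The compounds below may be only part of what the source reports. "The series", "measured", "known", "first", "only" and "open" are said of these compounds alone.

Compound 1 `CSc1nc(NCc2ccc(-c3ccccn3)cc2)c2[nH]nc(C(C)C)c2n1` — 2800 nM in a functional assay on HCT-116 cells (Homo sapiens) for cytotoxicity, read by fluorescence, with a stated time of 72 h; a lower number here means a stronger inhibitor, a higher number a weaker inhibitor
Compound 2 `CC(C)c1n[nH]c2c(NCc3ccc(-c4ccccn4)cc3)nc(NCC(C)(C)O)nc12` — 85 nM

Compound 1 gives the highest of the two numbers; its nearest neighbour is compound 2, reached by a 33-fold lower number from compound 1 to compound 2 (1.52 log units; beyond the scatter). Compound 3 `CC(C)c1n[nH]c2c(NCc3ccc(-c4ccccn4)cc3)nc(NCCN)nc12` differs from compound 1 by (2-aminoethyl)amino in place of methylsulfanyl on an aromatic carbon. Within the data shown here, the one measured step that bears on this, a 33-fold lower number from compound 1 to compound 2 (1.52 log units; beyond the scatter), also exchanged methylsulfanyl for an amino-linked chain and was large. A step of similar direction is therefore expected, a 23-fold lower number from compound 1 to compound 3 (1.37 log units; beyond the scatter). Compound 3 is estimated at 120 nM, with a range from 30 nM to 500 nM.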

Compound 3, half-maximal inhibitory concentration: 227 nM
For compound 3 the middle estimate is 1.9-fold (0.28 log units) below the measured one, and the stated range covers the measured number.
By their numbers in this assay, from the lowest: compound 2; then compound 3; then compound 1.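

In this assay, a second amino-linked chain in place of methylsulfanyl also lowers the number, a 12-fold lower number from compound 1 to compound 3 (1.09 log units; beyond the scatter), so the gain is not confined to the (2-hydroxy-2-methylpropyl)amino chain. The two chains are not equivalent at this position: a 2.7-fold higher number from compound 2 to compound 3 (0.43 log units; beyond the scatter). Nothing at hand explains the gap between them.

From the compounds shown here alone, the change from compound 2 to compound 3 alters both the chain end and its branching, so the contribution of each remains open. A (2-hydroxyethyl)amino chain would separate the two, while a longer chain ending in an amine would test chain length.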